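Swapping a chlorophenyl for a methylphenyl: expected cell tolerance

The compounds below may be only part of what the source reports. "The series", "measured", "known", "first", "only" and "open" are said of these compounds alone.

Compound 1 `O=C(COc1cccc2ccccc12)N/N=C/c1ccc(Br)cc1` gives > 100 ug/mL in an ADME assay on HEL cells (Homo sapiens) for cytotoxicity; a lower number here means that less compound is tolerated, a higher number that more compound is tolerated; this is a limit of the assay, not a number.
Compound 2 `O=C(COc1cccc2ccccc12)N/N=C/c1ccc([N+](=O)[O-])cc1` gives 20 ug/mL in this assay.
Compound 3 `O=C(COc1cccc2ccccc12)N/N=C/c1ccccc1Cl` gives 100 ug/mL in this assay.

Compound 3 holds the highest of the two plain numbers, with compound 2 nearest and lower. Compound 4 `Cc1ccc(/C=N/NC(=O)COc2cccc3ccccc23)cc1` differs from compound 3 by 4-methylphenyl in place of 2-chlorophenyl on a carbon with a double bond to nitrogen. Within the data shown here, no measured step makes this exact change. The closest is a number no higher from compound 1 to compound 3 (the limit leaves the size open), whose size stays hidden behind (the limit of > 100 ug/mL in this assay, at which 1 of the 3 values shown sits). The other step, an at least 5.0-fold lower number from compound 1 to compound 2 (0.69 log units; beyond the scatter), concerns a nitro group and does not touch this change. A step no larger than the scatter is therefore expected, no change at the digits printed from compound 3 to compound 4 (within the scatter). Compound 4 is estimated at 100 ug/mL, within 40 ug/mL to 250 ug/mL.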

Compound 4, minimum cytotoxic concentration: 20 ug/mL
The estimate for compound 4 lay 5.0-fold (0.70 log units) above the measured number; the measured number lies below the stated range.
By their numbers in this assay, from the lowest: compounds 2 and 4 (each within the scatter of the next); then compound 3.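

In this assay, 4-methylphenyl in place of 2-chlorophenyl gives a 5.0-fold lower number from compound 3 to compound 4 (0.70 log units; beyond the scatter), so this exchange on a carbon with a double bond to nitrogen is not a neutral one. Methyl in place of nitro on an aromatic carbon gives no change at the digits printed from compound 2 to compound 4 (within the scatter), so these two groups are not told apart here. Methyl in place of bromo gives an at least 5.0-fold lower number from compound 1 to compound 4 (0.69 log units; beyond the scatter), and the full size of that step stays open, as compound 1 stands at a limit of the assay: the limit of > 100 ug/mL in this assay, at which 1 of the 4 values shown sits.

Compound 3 and compound 4 differ in both the group and its place on the ring, so the compounds shown cannot say which of the two matters. On these data alone, how an amine or a carboxylic acid on that ring would fare also remains open.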